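This account rests on a few compounds, and the source may have more. Where it says the series, first, only, none or still open, it means among the compounds named here.

Measured compounds in an assay on isolated protein for inhibition of matrix metalloproteinase-9 (Homo sapiens); a lower number here means a stronger inhibitor, a higher number a weaker inhibitor:
compound 1 `COc1cccc(COC(=O)c2cccc(S)n2)c1` — 93000 nM
compound 2 `O=C(OCc1cccc(-c2ccccc2)c1)c1cccc(S)n1` — 50000 nM

Among the compounds with values here, compound 2 gives the lowest of the two numbers; its nearest neighbour is compound 1, and the only measured step, a 1.9-fold lower number from compound 1 to compound 2 (0.27 log units; within the scatter), lies within the scatter. Compound 2 therefore stands apart from compound 1 by no more than repeat measurements would.

Compound 3 `O=C(OCc1cccc(C(F)(F)F)c1)c1cccc(S)n1` is not yet measured. It differs from compound 2 in one place: trifluoromethyl in place of phenyl on an aromatic carbon. Within the data shown here, the single measured step bears on this change only indirectly, since it exchanged the same position from methoxy to phenyl and produced no step beyond the scatter. Among the measured compounds shown here, no measured step involves trifluoromethyl. For the measured compounds named here, with the one comparable exchange flat, the expectation for compound 3 is a number close to that of compound 2, with no step beyond the scatter in either direction: the expected step is a 1.4-fold higher number from compound 2 to compound 3 (0.15 log units; within the scatter). The estimate for compound 3 is 70000 nM, expected to fall between 30000 nM and 160000 nM.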

Compound 3, half-maximal inhibitory concentration: 126000 nM
Estimate against measurement, compound 3: 1.8-fold (0.26 log units) below, within the range that was stated.
By their numbers in this assay, from the lowest: compounds 2, 1 and 3 (each within the scatter of the next, the first and the last beyond it).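

In this assay this position now gives its first step beyond the scatter: a 2.5-fold higher number from compound 2 to compound 3 (0.40 log units; beyond the scatter) is modest, and it comes with trifluoromethyl in place of phenyl on an aromatic carbon. Trifluoromethyl in place of methoxy gives a 1.4-fold higher number from compound 1 to compound 3 (0.13 log units; within the scatter) and stays within the scatter, so the position separates compound 2 from compound 3 only, while compound 1 remains within the scatter of both. No data available here bear on why phenyl and trifluoromethyl differ at this position.

As far as these compounds go, whether an amine, a carboxylic acid or a longer chain at this position would move the number further in either direction remains open. From the compounds shown here alone, all three compounds keep the shared core, so the effect of any change elsewhere in it is also open.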